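This account rests on a few compounds, and the source may have more. Where it says the series, first, only, none or still open, it means among the compounds named here.

Working notes on the series. The shared core is seen in compound 3 `O=C(/C=C/c1cn(-c2ccccc2)nc1-c1ccncc1)c1ccsc1`; in a functional assay on Huh-7 cells (Homo sapiens) for inhibition, read by sulforhodamine B assay, with a stated time of 72 h (a higher number here means a weaker inhibitor, a lower number a stronger inhibitor), compound 3 gives 2200 nM. Compound 2 `O=C(/C=C/c1cn(-c2ccccc2)nc1-c1cccnc1)c1ccsc1` gives 1700 nM in this assay, and compound 1 `COc1ccc(OC)c(C(=O)/C=C/c2cn(-c3ccccc3)nc2-c2ccsc2)c1` gives 2100 nM. Compound 3 therefore sits with compound 1 and compound 2 inside the usual scatter of the method; none of the three values is separated from another beyond it. For the measured compounds named here, the one measured single-point change, a 1.3-fold higher number from compound 2 to compound 3 (0.11 log units; within the scatter), concerns the group on the aromatic carbon of the core and not the ketone side.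

Compound 4 `COc1ccc(OC)c(C(=O)/C=C/c2cn(-c3ccccc3)nc2-c2ccncc2)c1` is not yet measured. It differs from compound 3 by 2,5-dimethoxyphenyl in place of thiophen-3-yl on a carbonyl carbon. Going by the values given here, no measured pair differs in this place alone, so no step in this assay bears directly on it. Compound 1 carries the same 2,5-dimethoxyphenyl on the carbonyl carbon together with a thiophen-3-yl on the core, and its value lies with those of compound 2 and compound 3 within the scatter; that is all the numbers show.

Given this, the expected step of a 1.1-fold lower number from compound 3 to compound 4 (0.04 log units; within the scatter) is none beyond the scatter. The estimate for compound 4 in this assay is 2000 nM, with a range from 900 nM to 4500 nM.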

Compound 4, half-maximal inhibitory concentration: 1700 nM
For compound 4 the middle estimate is 1.2-fold (0.07 log units) above the measured one; low and high end bracket the measured number.
By their numbers in this assay, from the lowest: compounds 2, 4, 1 and 3 (each within the scatter of the next).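

In this assay, the carbonyl carbon now has a measured pair that differs in this place alone: 2,5-dimethoxyphenyl in place of thiophen-3-yl gives a 1.3-fold lower number from compound 3 to compound 4 (0.11 log units; within the scatter) with pyridin-4-yl held on the core, so the two groups cannot be told apart here. The aromatic carbon of the core also gains a comparison with a different group and a different ketone side: with 2,5-dimethoxyphenyl held on the carbonyl carbon, pyridin-4-yl in place of thiophen-3-yl gives a 1.2-fold lower number from compound 1 to compound 4 (0.09 log units; within the scatter) and thus adds no separation in this series. No supporting data accompany these results that could explain either step.

All the groups shown at these two places are aromatic, so the series does not yet show whether a place of this kind can separate compounds beyond the scatter. An aminoalkyl group or a carboxylic acid on the aromatic carbon of the core, or a longer saturated chain in place of the aromatic group on the carbonyl carbon, remains an open test of both places.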